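Trimming a Methyl From a Carboxylic Acid Side Chain

This account rests on a few compounds, and the source may have more. Where it says the series, first, only, none or still open, it means among the compounds named here.

Of the compounds shown here, three have been measured in a physicochemical assay for lipophilicity, at pH 7.4; a lower number here means a more polar compound, a higher number a more lipophilic compound. Compound 1 `CCOc1cc2[nH]c(Cc3nn(CC(=O)N4CCOCC4)c(=O)c4ccccc34)nc2cc1Cl` gives 3.32, compound 2 `COc1cc(OC)c(NC(=O)Cc2nn(CC(=O)O)c(=O)c3ccccc23)cc1Cl` gives 1.64, and compound 3 `C[C@H](C(=O)O)n1nc(Cn2cc3cc(OCC4CC4)c(Cl)cc3n2)c2ccccc2c1=O` gives 2.99. Compound 3 therefore stands second highest of the three: compound 1 lies a little above it, beyond the scatter, while compound 2 lies well below it, also beyond the scatter. Compound 4 `O=C(O)Cn1nc(Cn2cc3cc(OCC4CC4)c(Cl)cc3n2)c2ccccc2c1=O` has not yet been measured in this assay. It differs from compound 3 in one place: hydrogen in place of methyl on a saturated chain carbon bound to an aromatic nitrogen and a carbonyl carbon. Among the measured compounds shown here, no measured pair shows this same change, so nothing here fixes its size directly. Since one carbon leaves and nothing heavier enters, a small downward step is expected, a number 0.39 log units lower from compound 3 to compound 4 (beyond the scatter). For compound 4 the estimate is 2.6, within a range of 2.2 to 3.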

Compound 4, distribution coefficient: 2.79
Estimate against measurement, compound 4: 0.19 log units below, and the stated range covers the measured number.
By their numbers in this assay, from the lowest: compound 2; then compounds 4 and 3 (each within the scatter of the next); then compound 1.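

Among the compounds shown here, this pair gives the first direct reading at this position: in this assay, going from 1-carboxyethyl to carboxymethyl gives a number 0.20 log units lower from compound 3 to compound 4 (within the scatter), so this read-out does not separate the two compounds. The methyl on this saturated chain carbon can thus be exchanged for hydrogen here without a difference that stands clear of the scatter. Nothing available explains this result.

Going by these compounds, whether an ethyl group or a longer chain at this carbon would also stay within the scatter remains open. So does the effect of an amine there.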